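The source may hold more compounds than are shown below. What is called first, only, known or untested is meant among the compounds shown, and "the series" means these compounds.

Measured compounds:
compound 1, `COC(=O)c1ccc(C#CCCCCC(=O)c2ncc(-c3ccccn3)o2)cc1`: 25 nM
compound 2, `COC(=O)c1ccc(CCCCCCC(=O)c2ncc(-c3ccccn3)o2)cc1`: 1.5 nM

In an assay for inhibition of Fatty-acid amide hydrolase 1 (Rattus norvegicus) (a lower number here means a stronger inhibitor, a higher number a weaker inhibitor), compound 2 gives 1.5 nM, the lowest of the two numbers; its nearest neighbour is compound 1, whose value of 25 nM lies beyond the scatter. Compound 3, `COc1ccc(CCCCCCC(=O)c2ncc(-c3ccccn3)o2)cc1`, has not been measured. It differs from compound 2 as follows: methoxy in place of methoxycarbonyl on an aromatic carbon. The change sits on the aromatic ring at the end of the chain, para to a large group. Without a measured pair of this kind, only a small step is expected in this assay, toward a slightly higher number if any, estimated as a 2.0-fold higher number from compound 2 to compound 3 (0.30 log units; within the scatter). Compound 3 is expected to give 3 nM, within 0.7 nM to 15 nM.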

Compound 3, inhibition constant: 6.2 nM
The estimate for compound 3 lay 2.1-fold (0.32 log units) below the measured number; the range from low to high includes it.
By their numbers in this assay, from the lowest: compound 2; then compound 3; then compound 1.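

In this assay, methoxy in place of methoxycarbonyl on this aromatic carbon gives a 4.1-fold higher number from compound 2 to compound 3 (0.62 log units; beyond the scatter) and so shows that the group para to the large group affects the number, though only modestly. Compound 3 still gives 6.2 nM with the smaller group, which has one hydrogen-bond acceptor rather than two. No available measurement accounts for this step. The compounds shown leave open how a carboxylic acid, an amine or a plain hydrogen at this position would compare, and whether the same step would appear on the chain of compound 1.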